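The source may hold more compounds than are shown below. What is called first, only, known or untested is meant among the compounds shown, and "the series" means these compounds.

Measured compounds:

Compound 1, `CC(C)(C)C[C@@H](O)C(=O)N1[C@@H]2C[C@@H]2C[C@H]1C(=O)NCc1cc(Cl)ccc1-n1cnnn1` — in an ADME assay on Caco-2 cells (Homo sapiens) for permeability, read by LC-MS, in the apical to basolateral direction, with a stated time of 60 min, at pH 6.5 (a lower number here means that the compound crosses the layer more slowly, a higher number that the compound crosses the layer faster), compound 1 gives 24 10^-6 cm/s.
Compound 2, `CC(C)(C)[C@@H](O)C(=O)N1CC(=O)C[C@H]1C(=O)NCc1cc(Cl)ccc1-n1cnnn1` — in this assay compound 2 gives 0.8 10^-6 cm/s.
Compound 3, `CC(C)(C)C[C@@H](O)C(=O)N1[C@H](C(=O)NCc2cc(Cl)ccc2-n2cnnn2)C[C@@H]2C[C@@H]21` — in this assay compound 3 gives 25 10^-6 cm/s.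

Compound 1 stands second highest of the three numbers. Its nearest neighbour is compound 3, with a 1.0-fold higher number from compound 1 to compound 3 (0.02 log units; within the scatter), a step that rests only on the two compounds differing in configuration as drawn, so the two values are indistinguishable here (the fact that compounds 1 and 3 differ only in the configuration as drawn). Compound 2 lies far lower, but it differs from compound 1 in more than one place, so its value speaks only for itself.

The next compound, compound 4, `O=C(NCc1cc(Cl)ccc1-n1cnnn1)[C@@H]1C[C@H]2C[C@H]2N1C(=O)[C@H](O)CC1CC1`, has not yet been measured in this assay. It differs from compound 1 by cyclopropyl in place of tert-butyl on a saturated chain carbon, two bonds along the chain from a carbonyl carbon and an oxygen on a saturated carbon. Among the measured compounds shown here, none of the measured steps touches this part of the molecule; the single measured step concerns stereochemistry and shows no change beyond the scatter. There is therefore no measured guide to the size or direction of the step, and the expectation is that any change from compound 1 to compound 4 stays within the scatter.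

For compound 4 the estimated value in this assay is 20 10^-6 cm/s, with a range from 10 10^-6 cm/s to 40 10^-6 cm/s, which is expected to mean a 1.2-fold lower number from compound 1 to compound 4 (0.08 log units; within the scatter).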

Compound 4, apparent permeability: 6.9 10^-6 cm/s
Estimate against measurement, compound 4: 2.9-fold (0.46 log units) above; the whole stated range lies above it.
By their numbers in this assay, from the lowest: compound 2; then compound 4; then compounds 1 and 3 (each within the scatter of the next).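

Cyclopropyl in place of tert-butyl on this saturated chain carbon gives a 3.5-fold lower number from compound 1 to compound 4 (0.54 log units; beyond the scatter) in this assay. Among the compounds shown here, this is the first step that lies beyond the scatter and the first to touch this part of the molecule, so the number does respond to the group placed here, whereas the one earlier step concerned only configuration as drawn and stayed within the scatter. Nothing known about these compounds accounts for the size or direction of this step.

The step makes two changes at once, a ring entering and the heavy-atom count falling, and the compounds shown do not separate them. As far as these compounds go, how isopropyl, which carries no ring, a longer chain, an amine or a carboxylic acid would read at this position remains open.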